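Swapping Vinyl for Isobutyl: Expected Cytotoxicity of Compound 3

The source may report more compounds than this note shows. Statements on the series, on what has been measured and on what is new or still open speak of the compounds shown alone.

Compound 1 `O=c1c2ccccc2[se]n1C1CCCCC1`: > 40000 nM
Compound 2 `C=CCn1[se]c2ccccc2c1=O`: > 40000 nM

In a toxicity assay on PNT1A cells (Homo sapiens) for cytotoxicity, read by sulforhodamine B assay, with a stated time of 24 h (on this read-out higher numbers stand for weaker inhibition and lower numbers for stronger inhibition), compound 1 gives > 40000 nM, which is a limit of the assay and not a number. Compound 2 gives > 40000 nM in this assay, again a limit. The whole picture so far is the limit of > 40000 nM in this assay, at which 2 of the 2 values shown sit. Compound 3 `CC(C)CCn1[se]c2ccccc2c1=O` differs from compound 2 by isobutyl in place of vinyl on a saturated chain carbon bound to an aromatic nitrogen. Among the measured compounds shown here, no step between two measured compounds exists to gauge this change. The step from compound 2 to compound 3 is expected to be a number no higher from compound 2 to compound 3 (the limit leaves the size open), none beyond the scatter, so this assay will probably again report only a limit. Compound 3 is estimated at 40000 nM, ranging from 20000 nM to 100000 nM.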

Compound 3, half-maximal inhibitory concentration: > 40000 nM
Compound 3: a limit, no number (the forecaster's own chance of this, stated with the estimate: 85%); the middle value sits exactly at the limit.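

Among the compounds shown here, compound 2 and compound 3 both end at a limit of the assay, not a number, so no step between them can be read. The compounds shown leave open whether any change at this place would give a measurable number.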